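A few compounds are considered here, and "the series" means these few. Any claim that something is new, unique, unknown or untested is made for them only; others in the source may bear on it.

Compound 1, `COc1ccc2nccc(C3CN(C4CCN(C)CC4)C(=O)O3)c2c1`: in an in vitro functional assay on RBL cells for antagonist activity at C-C chemokine receptor type 8 (Homo sapiens), read by FLIPR and calcium flux (a higher number here means a weaker inhibitor, a lower number a stronger inhibitor), compound 1 gives < 50200 nM, which is a limit of the assay, not a number.
Compound 2, `CCCCCCN1CCC(N2CC(c3ccnc4ccc(OC)cc34)OC2=O)CC1`: in this assay compound 2 gives 501 nM.
Compound 3, `COc1ccc2nccc(C3CN(C4CCN(CC5CCCCC5)CC4)C(=O)O3)c2c1`: in this assay compound 3 gives 7940 nM.

Of the two numbers shown, compound 3 has the highest; its nearest neighbour is compound 2, and the step of a 16-fold higher number from compound 2 to compound 3 (1.20 log units; beyond the scatter) is beyond the scatter. The steps a step that the limit leaves unreadable from compound 1 to compound 2 and a step that the limit leaves unreadable from compound 1 to compound 3 cannot be read in size because of the limit of < 50200 nM in this assay, at which 1 of the 3 values shown sits.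

Compound 4, `COc1ccc(CN2CCC(N3CC(c4ccnc5ccc(OC)cc45)OC3=O)CC2)cc1`, has not yet been measured. It differs from compound 3 in one place: 4-methoxyphenyl in place of cyclohexyl on a saturated chain carbon bound to an amine nitrogen in a ring. Going by the values given here, the only readable step bearing on this place is a 16-fold higher number from compound 2 to compound 3 (1.20 log units; beyond the scatter), which shows that the group on this carbon can move the number by a large amount. Among the compounds with values here, no measured pair shows an aromatic ring against cyclohexyl here, so the direction for compound 4 is uncertain. Compound 4 is therefore expected to lie between the number of compound 2 and that of compound 3, and is estimated at 3000 nM, with a range from 500 nM to 20000 nM. This estimate means a step of a 2.6-fold lower number from compound 3 to compound 4 (0.42 log units; beyond the scatter) is expected from compound 3 to compound 4.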

Compound 4, half-maximal inhibitory concentration: 1260 nM
Compound 4: middle estimate off by 2.4-fold (0.38 log units), on the high side; the range from low to high includes it.
By their numbers in this assay, from the lowest: compound 2; then compound 4; then compound 3.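

In this assay, going by these compounds alone, 4-methoxyphenyl in place of cyclohexyl on a saturated chain carbon bound to an amine nitrogen in a ring gives a 6.3-fold lower number from compound 3 to compound 4 (0.80 log units; beyond the scatter), so two groups that each carry a six-membered ring are told apart at this place, and the earlier compounds held no such pair. The step with pentyl as the starting group, a 2.5-fold higher number from compound 2 to compound 4 (0.40 log units; beyond the scatter), shows that the 4-methoxyphenyl group recovers only part of what cyclohexyl gave up, and compound 2 keeps the lowest number of the three compounds that have one. The step from compound 1 to compound 4 cannot be read, like the other steps from compound 1, for the value of compound 1 is a limit and not a number: the limit of < 50200 nM in this assay, at which 1 of the 4 values shown sits.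

The compounds shown cannot tell whether the lower number of compound 4 comes from the aromatic ring itself or from its methoxy group, a question that an unsubstituted phenyl at this place would address. They also leave open whether a longer chain, such as heptyl in place of pentyl, would take the number lower than that of compound 2.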